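The compounds below may be only part of what the source reports. "The series", "measured", "known", "first", "only" and "open" are said of these compounds alone.

Of the compounds shown here, three built on one shared core have been tested in an assay on isolated protein for agonist activity at Free fatty acid receptor 1 (Homo sapiens); on this read-out lower numbers stand for an effect already at smaller amounts and higher numbers for an effect only at larger amounts of compound. Compound 1 `CC#CC(CC(=O)O)c1ccc(OCc2ccn3cc(-c4ccc(C)cc4C)nc3c2)cc1` gives 503 nM. Compound 2 `CC#CC(CC(=O)O)c1ccc(OCc2ccc3nc(-c4ccccc4C)cn3c2)cc1` gives 389 nM, the lowest of the three numbers. Compound 3 `CC#CC(CC(=O)O)c1ccc(OCc2ccn3cc(-c4cccc(C)c4)nc3c2)cc1` gives 1510 nM. The numbers for compound 2 and compound 1 lie within the usual scatter of each other, whereas the number for compound 3 lies beyond it. For the measured compounds named here, the only single-place step among the measured compounds is a 3.0-fold higher number from compound 1 to compound 3 (0.48 log units; beyond the scatter), which shows that the methyl pattern on this ring has a modest influence. Compound 4 `CC#CC(CC(=O)O)c1ccc(OCc2ccc3nc(-c4ccc(C)cc4C)cn3c2)cc1` differs from compound 2 by methyl in place of hydrogen on an aromatic carbon. Going by the values given here, no measured step repeats this exact change; the step from compound 1 to compound 3 touches the same ring and was modest, and compound 1, which carries the same 2,4-dimethylphenyl as compound 4 on a differently joined core, gives a number close to compound 2. The expected step is therefore a 1.1-fold lower number from compound 2 to compound 4 (0.05 log units; within the scatter), nothing beyond the scatter. Compound 4 is estimated at 350 nM, within a range from 150 nM to 800 nM.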

Compound 4, half-maximal effective concentration: 316 nM
For compound 4 the middle estimate is 1.1-fold (0.04 log units) above the measured one; measured number inside the range.
By their numbers in this assay, from the lowest: compounds 4, 2 and 1 (each within the scatter of the next); then compound 3.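

Adding a methyl group to the 2-methylphenyl of compound 2, at the place para to a large group and meta to a methyl group, gives a 1.2-fold lower number from compound 2 to compound 4 (0.09 log units; within the scatter) in this assay and so makes no difference that can be told from repeat scatter. The earlier compounds shown here offered no step that isolated this one position, and this step shows that on the core of compound 2, the 2,4-dimethylphenyl and 2-methylphenyl groups read alike. No available evidence accounts for this result.

Going by these compounds, it remains open how a different group at this place, such as an amine or a longer chain like propyl, would read. On these data alone, it is also open whether this same methyl would behave alike on the core of compound 1.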